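Swapping fluorophenyl for dichlorophenyl in a sulfonamide series

This account rests on a few compounds, and the source may have more. Where it says the series, first, only, none or still open, it means among the compounds named here.

Compound 1 `O=S(=O)(Nc1ccc(-c2nc3ccccc3o2)cc1)c1cccc(F)c1` was tested in an ADME assay on HEK293 cells (Homo sapiens) for cytotoxicity, read by resazurin assay, with a stated time of 48 h; on this read-out lower numbers stand for higher toxicity in this test and higher numbers for lower toxicity in this test. In this assay compound 1 gives > 100000 nM, which is a limit of the assay rather than a number. Two further compounds share its core with a different pattern of substitution. Compound 2 `O=S(=O)(Nc1ccc2oc(-c3ccccc3)nc2c1)c1cccc(O)c1` gives in this assay > 100000 nM, again a limit of the assay. Compound 3 `Cc1cccc(S(=O)(=O)Nc2ccc3oc(-c4ccccc4)nc3c2)c1` gives in this assay 69000 nM. For the measured compounds named here, the only measured single step, methyl in place of hydroxy on an aromatic carbon, amounts to an at least 1.4-fold lower number from compound 2 to compound 3 (0.16 log units; that floor lies within the scatter), so that step does not rise above the scatter. Across the three values, the limit of > 100000 nM in this assay, at which 2 of the 3 values shown sit, shows how little of the range has yet been resolved.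

Compound 4 `O=S(=O)(Nc1ccc(-c2nc3ccccc3o2)cc1)c1ccc(Cl)c(Cl)c1` is the compound not yet measured. It differs from compound 1 in one place: 3,4-dichlorophenyl in place of 3-fluorophenyl on a sulfonyl sulfur. Going by the values given here, no measured step covers a change at the sulfonyl sulfur, and the one step that exists, from compound 2 to compound 3, concerns another part of the molecule and is small. The expectation therefore rests on the weak hint of compound 3 with 69000 nM that some analogues in this assay do give numbers. Compound 4 is estimated to give 70000 nM in this assay, within 25000 nM to 200000 nM. The estimated step from compound 1 to compound 4, an at least 1.4-fold lower number from compound 1 to compound 4 (0.15 log units; that floor lies within the scatter), would be expected to be modest, if present at all.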

Compound 4, half-maximal cytotoxic concentration: > 100000 nM
Compound 4: a limit, no number (the forecaster's own chance of this, stated with the estimate: 45%); middle value at least 1.4-fold (0.15 log units) away from the limit.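

Compound 1 and compound 4 both give only a limit of the assay in this assay, so no step can be read between them. The compounds shown leave open whether 3,4-dichlorophenyl in place of 3-fluorophenyl on a sulfonyl sulfur changes the number at all, and little of the range is resolved: the limit of > 100000 nM in this assay, at which 3 of the 4 values shown sit.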